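This account rests on a few compounds, and the source may have more. Where it says the series, first, only, none or still open, it means among the compounds named here.

Measured so far:
compound 1 `O=C(Nc1ccccc1)Nc1ccc2c(c1)COC2=O` — 7090 nM
compound 2 `O=C(Nc1ccc(F)cc1)C(=O)Nc1ccc2c(c1)COC2=O` — 570 nM

Both compounds carry the same core and were measured in a functional assay on cells (T-cell, Mus musculus) for inhibition; a lower number here means a stronger inhibitor, a higher number a weaker inhibitor. Compound 2 gives 570 nM, the lowest number of the two; compound 1 gives 7090 nM, a gap beyond the scatter, so compound 2 stands as the stronger inhibitor of the pair on these numbers alone. Going by the values given here, no single-point step between measured compounds is available, so the effect of a change at the aryl end of the series is not known from data.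

Compound 3 `Cc1ccccc1NC(=O)C(=O)Nc1ccc2c(c1)COC2=O` differs from compound 2 in one place: 2-methylphenyl in place of 4-fluorophenyl on an amide-type nitrogen. The change sits on the amide-type nitrogen whose other neighbour is a carbonyl carbon. Among the compounds with values here, nothing measured so far speaks to this exchange, and there is no reason in the data to expect a large move in either direction. The step from compound 2 to compound 3 is expected to be small, near the scatter, perhaps toward a somewhat higher number: a 1.6-fold higher number from compound 2 to compound 3 (0.20 log units; within the scatter). For compound 3 the estimate in this assay is 900 nM, with a range from 300 nM to 3000 nM.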

Compound 3, half-maximal inhibitory concentration: 5510 nM
Compound 3: the middle estimate sits 6.1-fold (0.79 log units) below what was measured, and the stated range ends below it.
By their numbers in this assay, from the lowest: compound 2; then compounds 3 and 1 (each within the scatter of the next).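

In this assay the aryl group on the amide-type nitrogen proves to be a position that responds to change: 2-methylphenyl in place of 4-fluorophenyl gives a 9.7-fold higher number from compound 2 to compound 3 (0.99 log units; beyond the scatter). This is the only direct reading at this place among the compounds shown, and it makes clear that the number can move this far even though the two groups match in heavy-atom count, each has one six-membered aromatic ring of carbon only, and neither has a hydrogen-bond donor, a hydrogen-bond acceptor or a net charge. No measurement at hand bears on the origin of this step, which therefore stands as an observation only.

The exchange alters both the substituent and its numbered place on the ring, so the compounds shown cannot separate these two changes; a pair such as 4-methylphenyl and 2-fluorophenyl would address that question. Also open, on these data alone, is how this position would respond to a group of a different kind, such as an amine or a carboxylic acid on the phenyl ring.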